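This account rests on a few compounds, and the source may have more. Where it says the series, first, only, none or still open, it means among the compounds named here.

Among the compounds with values here, compound 2 `CCCCCCCCCCc1cc2cn(COCCO)c(O)nc-2n1` is the only compound here with a definite number: in a functional assay on HEL cells (Homo sapiens) (on this read-out higher numbers stand for lower toxicity in this test and lower numbers for higher toxicity in this test), compound 2 gives 32000 nM. Compound 1 `CCCCCCc1cc2cn(COCCO)c(O)nc-2n1` reached only the limit of the test, so in this assay compound 1 gives > 200000 nM, a limit rather than a number. Within the data shown here, the one measured step runs from the shorter chain to the longer one: an at least 6.2-fold lower number from compound 1 to compound 2 (0.79 log units; beyond the scatter), which rests on (the limit of > 200000 nM in this assay, at which 1 of the 2 values shown sits).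

Compound 3 `CCCCCCCc1cc2cn(COCCO)c(O)nc-2n1` differs from compound 2 by hydrogen in place of propyl on a saturated chain carbon, seven bonds along the chain from an aromatic carbon. This is the same kind of change as the measured step, run in the opposite direction and over a shorter piece of chain. Taking part of the chain away is therefore expected to move the number upward, toward less toxicity, by something between no change and the size seen from compound 1 to compound 2. Since the measured step was at least modest, compound 3 is expected to show a 2.8-fold higher number from compound 2 to compound 3 (0.45 log units; beyond the scatter). The estimate for compound 3 in this assay is 90000 nM, with a range from 35000 nM to 200000 nM.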

Compound 3, half-maximal cytotoxic concentration: 119000 nM
Compound 3: middle estimate off by 1.3-fold (0.12 log units), on the low side; the measured number falls inside the stated range.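

In this assay, within the data shown here, the change at this place, on a saturated chain carbon, seven bonds along the chain from an aromatic carbon, has a clear effect: removing the propyl gives a 3.7-fold higher number from compound 2 to compound 3 (0.57 log units; beyond the scatter), so the shorter chain of compound 3 goes with lower toxicity in this test, and this pair is the first in which both compounds have definite numbers. At the short end of the series, the step for one added methyl is an at least 1.6-fold lower number from compound 1 to compound 3 (0.22 log units; that floor lies within the scatter), so these values cannot show whether that single methyl changes toxicity at all. Compound 1 stands at a limit rather than a definite number, so that step gives only a floor and its true size stays unknown: the limit of > 200000 nM in this assay, at which 1 of the 3 values shown sits.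

The three chains shown do not reveal how the number changes with each added carbon, or whether it changes evenly along the series or mostly over one part of it. Going by these compounds, neither a longer chain than that of compound 2 nor an amine at the end of the chain is covered, so the effect of either on toxicity in this test remains open.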